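The compounds below may be only part of what the source reports. "The series", "measured", "known", "first", "only" and "open" are said of these compounds alone.

Compound 1 `O=C(/C=C/c1ccc2c(ccc[n+]2[O-])c1)c1ccc(F)cc1` gives 4.3 ug/mL in a functional assay on MCF7 cells (Homo sapiens) for antiproliferative activity, read by sulforhodamine B assay, with a stated time of 48 h (a higher number here means a weaker inhibitor, a lower number a stronger inhibitor), and compound 2 `O=C(/C=C/c1ccc2c(ccc[n+]2[O-])c1)c1ccc(Br)cc1` gives 6.6 ug/mL. The step of a 1.5-fold higher number from compound 1 to compound 2 (0.19 log units; within the scatter) is small. Compound 2 therefore holds the highest of the two numbers, with compound 1 nearest and within the scatter. Compound 3 `Cc1ccc(C(=O)/C=C/c2ccc3c(ccc[n+]3[O-])c2)cc1` differs from compound 2 by methyl in place of bromo on an aromatic carbon. Going by the values given here, only one earlier step bears on this, the swap on an aromatic carbon from compound 1 to compound 2, and it stayed within the scatter; the expected step of a 1.2-fold lower number from compound 2 to compound 3 (0.08 log units; within the scatter) is likewise none beyond the scatter. Compound 3 is estimated at 5.5 ug/mL, with a range from 2.5 ug/mL to 12 ug/mL.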

Compound 3, half-maximal inhibitory concentration: 8.3 ug/mL
Beside the measured number, compound 3's estimate is 1.5-fold (0.18 log units) below it; the measured number falls inside the stated range.
By their numbers in this assay, from the lowest: compounds 1, 2 and 3 (each within the scatter of the next).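

Replacing the halogen with a carbon group at this place, para to a large group, gives a step in this assay of (a 1.3-fold higher number from compound 2 to compound 3 (0.10 log units; within the scatter)) and, measured against the fluoro compound, of (a 1.9-fold higher number from compound 1 to compound 3 (0.29 log units; within the scatter)). Both steps stay within the scatter, so the data separate neither halogen from methyl at this position. No available evidence bears on these numbers.

Going by these compounds, whether an amine, a carboxylic acid or a longer chain at this place would give a step beyond the scatter remains open. So does the effect of any change to the shared core.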